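This account rests on a few compounds, and the source may have more. Where it says the series, first, only, none or still open, it means among the compounds named here.

Compound 1 `COc1ccc(C2=NO[C@]3(C2)C(=O)O[C@@H]2[C@H]3CC[C@H](C)[C@]3(O)C=CC(=O)[C@@]23C)cc1` sits at the polar end of the three numbers shown: in a physicochemical assay for lipophilicity (a lower number here means a more polar compound, a higher number a more lipophilic compound), compound 1 gives 1.47. Compound 3 `C[C@H]1CC[C@@H]2[C@@H](OC(=O)[C@]23CC(c2ccc(N(C)C)cc2)=NO3)[C@]2(C)C(=O)C=C[C@@]12O` gives 1.51 in this assay, and compound 2 `C[C@H]1CC[C@@H]2[C@@H](OC(=O)[C@]23CC(c2ccccc2Br)=NO3)[C@]2(C)C(=O)C=C[C@@]12O` gives 2.22. Among the measured steps, a number 0.75 log units higher from compound 1 to compound 2 (beyond the scatter), while a number 0.04 log units higher from compound 1 to compound 3 (within the scatter). Compound 4 `COc1ccc(C2=NO[C@]3(C2)C(=O)O[C@@H]2[C@H]3CC[C@H](C)[C@]3(O)C=CC(=O)[C@@]23C)cc1OC` differs from compound 1 by a single small addition. methoxy in place of hydrogen on an aromatic carbon Neither measured step adds a group in this way; both exchange one aromatic substituent for another, and the exchange of dimethylamino for methoxy left the number unchanged within the scatter. A second methoxy is expected to shift this assay only slightly, so the step of a number 0.08 log units higher from compound 1 to compound 4 (within the scatter) is expected to stay within the scatter. Compound 4 is therefore estimated at 1.55, with a range from 1.25 to 1.85.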

Compound 4, partition coefficient: 1.06
Estimate against measurement, compound 4: 0.49 log units above; the measured number lies below the stated range.
By their numbers in this assay, from the lowest: compound 4; then compounds 1 and 3 (each within the scatter of the next); then compound 2.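

In this assay, going by these compounds alone, methoxy added on an aromatic carbon ortho to a methoxy group gives a number 0.41 log units lower from compound 1 to compound 4 (beyond the scatter), a fall that no earlier step starting from compound 1 showed. With 3,4-dimethoxyphenyl as the group, the exchanges give a number 0.45 log units lower from compound 3 to compound 4 (beyond the scatter) and a number 1.16 log units lower from compound 2 to compound 4 (beyond the scatter), which places compound 4 beyond the scatter at the low end of the series. Nothing available explains this fall. On these data alone, whether a hydroxyl, an amine or a carboxylic acid on this same carbon would also lower the number stays open, as does the effect of methoxy here without the first methoxy group.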